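Methoxy in Place of Bromo on the Pendant Phenyl

A few compounds are considered here, and "the series" means these few. Any claim that something is new, unique, unknown or untested is made for them only; others in the source may bear on it.

Compound 2 `O=C(Nc1cc(-c2ccccc2)nn1-c1cccc(Br)c1)c1ccccc1` gives 400 nM in a functional assay on cells for positive allosteric modulation of metabotropic glutamate receptor 5 (Rattus norvegicus), read by calcium flux (a lower number here means that less compound is needed, a higher number that more compound is needed for the effect), the highest of two numbers measured, though its nearest neighbour, compound 1 `O=C(Nc1cc(-c2ccccc2)nn1-c1ccccc1)c1ccccc1`, gives 203 nM and the step of a 2.0-fold higher number from compound 1 to compound 2 (0.29 log units; within the scatter) lies within the scatter. Compound 3 `COc1cccc(-n2nc(-c3ccccc3)cc2NC(=O)c2ccccc2)c1` carries methoxy in place of bromo on an aromatic carbon. Going by the values given here, no measured step exchanges one substituent at that position for another; the only step seen at this place, hydrogen to bromo, stayed within the scatter. A step of similar small size is therefore expected, a 1.1-fold lower number from compound 2 to compound 3 (0.06 log units; within the scatter), with no firm direction. Compound 3 is expected to give about 350 nM, between 120 nM and 1000 nM.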

Compound 3, half-maximal effective concentration: 570 nM
For compound 3 the middle estimate is 1.6-fold (0.21 log units) below the measured one; low and high end bracket the measured number.
By their numbers in this assay, from the lowest: compounds 1, 2 and 3 (each within the scatter of the next, the first and the last beyond it).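

The exchange of bromo for methoxy gives a 1.4-fold higher number from compound 2 to compound 3 (0.15 log units; within the scatter) and so does not set the two groups apart in this assay. Going by these compounds alone, measured against compound 1, which carries hydrogen at this place, methoxy gives a 2.8-fold higher number from compound 1 to compound 3 (0.45 log units; beyond the scatter) and is the first step here to clear the scatter, though only modestly. Nothing at hand gives a reason for this step.

As far as these compounds go, whether an amine or a carboxylic acid at this place would stay as close to compound 1 remains open. So does whether a longer chain, such as ethoxy, would go further than methoxy.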